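A Smaller Group on a Carbonyl, Tested for Cell Toxicity

The source may hold more compounds than are shown below. What is called first, only, known or untested is meant among the compounds shown, and "the series" means these compounds.

Of the compounds shown here, three have been measured so far in an ADME assay on HepG2 2.2.15 cells (Homo sapiens) for cytotoxicity, read by MTT assay (on this read-out higher numbers stand for lower toxicity in this test and lower numbers for higher toxicity in this test), and all of them show little toxicity. Compound 1 `COc1ccc(/C=C/C(=O)Oc2ccc(C(C)=O)cc2)cc1OC` gives > 2610000 nM and this value is a limit of the assay. Compound 2 `COc1cc(C(=O)Oc2ccc(C(C)=O)cc2)cc(OC)c1OC` gives 1210000 nM as a true number. Compound 3 `COc1cccc(/C=C/C(=O)OC[C@H]2O[C@@H](Oc3ccc(C(C)=O)cc3)[C@H](O)[C@@H](O)[C@@H]2O)c1` gives > 1510000 nM and this value is likewise a limit. Compound 3 therefore has no exact position on the scale, and only one of the three results is a true number.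

Compound 4 `CC(=O)c1ccc(O[C@@H]2O[C@H](COC(=O)c3ccccc3)[C@@H](O)[C@H](O)[C@H]2O)cc1` has not been measured yet. It keeps the core of compound 3 and changes a single group, with phenyl in place of 2-(3-methoxyphenyl)ethenyl on a carbonyl carbon. The counted difference is phenyl in place of 2-(3-methoxyphenyl)ethenyl on a carbonyl carbon and everything else stays the same.

Among the compounds with values here, no two measured compounds differ in only one place, so no measured step can serve as a guide for this change. For that reason, no shift beyond the usual scatter is expected in either direction. Expected here is a step that the limit leaves unreadable from compound 3 to compound 4 and that estimate lies within the usual scatter of this assay with no clear direction. Compound 4 is estimated at 1800000 nM with an expected range from 900000 nM to 2800000 nM and its result may also turn out to be a limit.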

Compound 4, half-maximal cytotoxic concentration: 1050000 nM
Compound 4: the middle estimate sits 1.7-fold (0.23 log units) above what was measured, and the stated range covers the measured number.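

Within the data shown here, the change of phenyl in place of 2-(3-methoxyphenyl)ethenyl on a carbonyl carbon gives the only step measured so far in this assay, with an at least 1.4-fold lower number from compound 3 to compound 4 (0.15 log units; that floor lies within the scatter). Going by these compounds, compound 3 carries a limit and not a true number, so this step gives only a floor on the change and its real size stays unknown: the limit of > 1510000 nM in this assay, at which 1 of the 4 values shown sits. Compound 4 gives 1050000 nM, a true number rather than a limit, which shows that a sugar-bearing compound of this series can be placed exactly on the scale, and that with the smaller phenyl group on the carbonyl it still needs a very high concentration to harm these cells.

On these data alone, with a single step, it remains open whether the double bond, the methoxy group or the overall size of the departing group matters here, and a 2-phenylethenyl group, which keeps the double bond without the methoxy group, would help to separate these. Also open, as far as these compounds go, is what an amine, a carboxylic acid or a longer chain at this same place on the carbonyl carbon would do to the reading.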